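From dimethylamino to propylsulfanyl on the shared core

The compounds below may be only part of what the source reports. "The series", "measured", "known", "first", "only" and "open" are said of these compounds alone.

Of the compounds shown here, three sharing one core have been tested in an ADME assay on Akata cells (Homo sapiens) for cytotoxicity, with a stated time of 7 days; on this read-out lower numbers stand for higher toxicity in this test and higher numbers for lower toxicity in this test: compound 1 (`CNc1nc(N)nc2c1ncn2/C=C1/CC1(CO)CO`), compound 2 (`CC(C)CSc1nc(N)nc2c1ncn2/C=C1/CC1(CO)CO`) and compound 3 (`CN(C)c1nc(N)nc2c1ncn2/C=C1/CC1(CO)CO`). Compound 1 gives > 24000 nM as a limit of the assay. Compound 2 gives > 20000 nM and this too is a limit. Compound 3 gives > 24000 nM and this is again a limit and not a number. Compound 3 therefore has no exact place on the scale, and neither of the other two offers a number to set it against.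

Compound 4 (`CCCSc1nc(N)nc2c1ncn2/C=C1/CC1(CO)CO`) carries propylsulfanyl in place of dimethylamino on an aromatic carbon. The closest measured change is a step that the two limits leave unreadable from compound 2 to compound 3 and it also exchanges a sulfanyl group and dimethylamino. Alongside it stand a step that the two limits leave unreadable from compound 1 to compound 2 and a step that the two limits leave unreadable from compound 1 to compound 3 and neither gives a size or direction. Among the compounds with values here, the expectation therefore rests mainly on compound 2 and its limit of > 20000 nM as the only measured compound with a sulfanyl group. No step beyond the usual scatter is expected, and the estimated change is an at least 1.0-fold lower number from compound 3 to compound 4 (0.03 log units; that floor lies within the scatter) with no firm direction. Compound 4 is estimated at 22000 nM with an expected range from 10000 nM to 50000 nM. A limit rather than a number is also expected for compound 4.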

Compound 4, half-maximal cytotoxic concentration: > 20000 nM
Compound 4: no number, only a limit (the forecaster's own chance of this, stated with the estimate: 75%); the middle value is on the limit's open side.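

In this assay compound 4 gives > 20000 nM, which is a limit of the assay and not a number. Within the data shown here, compound 1, compound 2 and compound 3 also stand only as limits, so no step to compound 4 can be read. The compounds shown leave open where any of the four truly lies on this scale, and whether exchanging the group on the shared core changes the read-out at all.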